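Carboxy in Place of Sulfamoyl: Expecting Compound 4

The compounds below may be only part of what the source reports. "The series", "measured", "known", "first", "only" and "open" are said of these compounds alone.

Measured compounds:
compound 1, `CCCS(=O)(=O)Nc1ccc(F)c(C(=O)c2n[nH]c3ncc(-c4ccc(C(C)(C)C)cc4)cc23)c1F`: 46%
compound 2, `CCCS(=O)(=O)Nc1ccc(F)c(C(=O)c2n[nH]c3ncc(-c4ccc(Cl)c(C(F)(F)F)c4)cc23)c1F`: 15%
compound 3, `CCCS(=O)(=O)Nc1ccc(F)c(C(=O)c2n[nH]c3ncc(-c4ccc(S(N)(=O)=O)cc4)cc23)c1F`: 0.25%

In an assay for binding affinity to dual specificity mitogen-activated protein kinase kinase 4 (Homo sapiens), read by KINOMEscan, tested at 100 nM (on this read-out lower numbers stand for a stronger effect and higher numbers for a weaker effect at the one concentration tested), compound 3 gives 0.25%, the lowest of the three numbers. The nearest neighbour is reached by the step of a number 14.8 percentage points lower from compound 2 to compound 3 (beyond the scatter), the furthest by the step of a number 45.8 percentage points lower from compound 1 to compound 3 (beyond the scatter).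

Compound 4, `CCCS(=O)(=O)Nc1ccc(F)c(C(=O)c2n[nH]c3ncc(-c4ccc(C(=O)O)cc4)cc23)c1F`, differs from compound 3 in one place: carboxy in place of sulfamoyl on an aromatic carbon. For the measured compounds named here, both measured changes at that position were downward, the one from compound 1 large and the one from compound 2 modest. Since compound 3 already sits near the floor of this assay, and the incoming group keeps a hydrogen-bond donor and an acceptor, compound 4 is expected to show a number 3.8 percentage points higher from compound 3 to compound 4 (within the scatter), a change not clearly beyond the scatter. Compound 4 is therefore estimated at 4%, with a range from 0.1% to 30%.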

Compound 4, a percentage reported as activity, at one concentration (the size of the read-out at that concentration, not a potency): 0.1%
The estimate for compound 4 lay 3.9 percentage points above the measured number, and the stated range covers the measured number.
By their numbers in this assay, from the lowest: compounds 4 and 3 (each within the scatter of the next); then compound 2; then compound 1.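

In this assay, carboxy and sulfamoyl on this aromatic carbon, para to a large group, cannot be told apart, with a number 0.2 percentage points lower from compound 3 to compound 4 (within the scatter). The carboxy compound keeps the clear separation from the other two groups, with a number 14.9 percentage points lower from compound 2 to compound 4 (beyond the scatter) and a number 45.9 percentage points lower from compound 1 to compound 4 (beyond the scatter), so this position accepts more than one of the groups shown. No measurement offered here explains this result. On these data alone, it remains open whether a primary amide, a methyl ester or an amine at this position would read alike. As far as these compounds go, with only one tested concentration, any difference between compound 3 and compound 4 at other concentrations also remains open.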